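This account rests on a few compounds, and the source may have more. Where it says the series, first, only, none or still open, it means among the compounds named here.

Of the compounds shown here, two sharing a common core have so far been measured in an ADME assay on a cell-free system (plasma, Homo sapiens); a higher number here means a larger unbound share of the compound, a lower number a smaller unbound share. Among the compounds with values here, compound 1 (`CCCS(=O)(=O)c1ccc(F)c(C#Cc2cc(Cl)ccc2OCC(=O)O)c1`) gives 0.01 and compound 2 (`CS(=O)(=O)c1ccc(Cl)c(C#Cc2cc(Cl)ccc2OCC(=O)O)c1`) gives 0.007, so compound 2 stands within the scatter of the only other measured compound. Compound 3 (`CS(=O)(=O)c1ccc(F)c(C#Cc2cc(Cl)ccc2OCC(=O)O)c1`) follows from compound 2 by one exchange, fluoro in place of chloro on an aromatic carbon, ortho to a large group and para to a methylsulfonyl group: fluoro in place of chloro on an aromatic carbon. Within the data shown here, the two measured compounds differ in more than one place, so no direct step shows what this exchange does. Among the measured compounds shown here, the only indirect guide is compound 1, which also carries fluoro on that carbon and gives 0.01. A small rise in the unbound fraction is expected, with the estimated step of a 1.6-fold higher number from compound 2 to compound 3 (0.20 log units; within the scatter) staying within the scatter. For compound 3 the expected value is 0.011, with an estimated range of 0.006 to 0.02.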

Compound 3, unbound fraction: 0.013
For compound 3 the middle estimate is 1.2-fold (0.07 log units) below the measured one; measured number inside the range.
By their numbers in this assay, from the lowest: compounds 2, 1 and 3 (each within the scatter of the next).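

In this assay, the exchange of chloro for fluoro on the aromatic carbon ortho to a large group and para to a methylsulfonyl group can now be read directly: a 1.9-fold higher number from compound 2 to compound 3 (0.27 log units; within the scatter), so the two halogens are not told apart at this position. The sulfonyl chain can also be read on its own, since hydrogen in place of ethyl on a saturated chain carbon bound to a sulfonyl sulfur gives a 1.3-fold higher number from compound 1 to compound 3 (0.11 log units; within the scatter), and this change does not separate the compounds either. Nothing available accounts for either step.

As far as these compounds go, it remains open whether a nitrile or a methoxy group on that aromatic carbon, or a longer chain on the sulfonyl group, would give a step beyond the scatter. From the compounds shown here alone, it is equally open what an amide in place of the carboxylic acid would do to the unbound fraction.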